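Phenoxy in place of (2-aminophenyl)amino on the carbonyl

The compounds below may be only part of what the source reports. "The series", "measured", "known", "first", "only" and "open" are said of these compounds alone.

In a functional assay on blood (Homo sapiens), with a stated time of 60 min, in the presence of a further agent that is not named here (on this read-out lower numbers stand for an effect already at smaller amounts and higher numbers for an effect only at larger amounts of compound), compound 2 (`COc1ccc(S(=O)(=O)C2(C(=O)Nc3ccccc3N)CCC3(CCNCC3)C2)cc1Cl`) gives 7500 nM. Compound 1 (`Nc1ccccc1NC(=O)C1(S(=O)(=O)c2ccc(Oc3ccc(OC(F)(F)F)cc3)c(Cl)c2)CCC2(CCNCC2)C1`) gives 3700 nM, beyond the scatter from compound 2, and compound 3 (`COc1ccc(S(=O)(=O)C2(C(=O)Nc3cc(-c4ccccc4)ccc3N)CCC3(CCNCC3)C2)cc1Cl`) gives 15000 nM, within it. Compound 4 (`COc1ccc(S(=O)(=O)C2(C(=O)Oc3ccccc3)CCC3(CCNCC3)C2)cc1Cl`) has phenoxy in place of (2-aminophenyl)amino on a carbonyl carbon.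

Two measured steps offer some guidance. One is a 2.0-fold higher number from compound 1 to compound 2 (0.31 log units; beyond the scatter), with methyl in place of 4-(trifluoromethoxy)phenyl on an oxygen. The other is a 2.0-fold higher number from compound 2 to compound 3 (0.30 log units; within the scatter), with phenyl in place of hydrogen on an aromatic carbon. Both are small, but neither replaces the group on the carbonyl carbon, so they guide only loosely.

With that whole group replaced, a larger step is expected, towards a higher number: a 3.3-fold higher number from compound 2 to compound 4 (0.52 log units; beyond the scatter). For compound 4 the estimated value is 25000 nM, with an expected range of 7000 nM to 100000 nM.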

Compound 4, half-maximal effective concentration: 3700 nM
Compound 4: the middle estimate sits 6.8-fold (0.83 log units) above what was measured; the whole stated range lies above it.
By their numbers in this assay, from the lowest: compounds 1 and 4 (each within the scatter of the next); then compounds 2 and 3 (each within the scatter of the next).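

In this assay the (2-aminophenyl)amino group on the carbonyl carbon proves replaceable: phenoxy gives a 2.0-fold lower number from compound 2 to compound 4 (0.31 log units; beyond the scatter) and does not push the number up. The amide hydrogen and the amino group are therefore not required for activity in this series, since phenoxy carries no hydrogen-bond donors. Nothing measured here explains the direction of this modest step. Still open, as far as these compounds go, is how a plain phenylamino group, which keeps the amide hydrogen but lacks the amino group, would compare. So is whether a smaller methoxy on the carbonyl carbon would hold this level.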